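The compounds below may be only part of what the source reports. "The series", "measured", "known", "first", "only" and "open" are said of these compounds alone.

Three compounds have been measured in a functional assay on the whole organism (strain Icem-CET (SPF Caw)) for inhibition, with Mus musculus as the target, with a stated time of 30 min; on this read-out higher numbers stand for an effect only at larger amounts of compound and lower numbers for an effect already at smaller amounts:

Compound 1, `C#CCNC(=O)/C(C)=C(\C)c1ccc(Br)cc1`, gives 18.4 mg/kg.
Compound 2, `C=CCNC(=O)/C(C)=C(\C)c1ccc(Br)cc1`, gives 33.7 mg/kg.
Compound 3, `C/C(C(=O)NC1CC1)=C(/C)c1ccc(Br)cc1`, gives 8.2 mg/kg.

Compound 2 stands at the highest of these three numbers. Its nearest neighbour is compound 1, and the step of a 1.8-fold higher number from compound 1 to compound 2 (0.26 log units; within the scatter) lies within the usual scatter, so the two cannot be told apart. Its furthest neighbour is compound 3, reached by a 4.1-fold lower number from compound 2 to compound 3 (0.61 log units; beyond the scatter); in the same direction, a 2.2-fold lower number from compound 1 to compound 3 (0.35 log units; beyond the scatter). All three measured steps change only the group on the amide-type nitrogen; the aromatic ring carries bromo in every measured compound.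

Compound 4, `C=CCNC(=O)/C(C)=C(\C)c1ccc(C)cc1`, differs from compound 2 in another place: methyl in place of bromo on an aromatic carbon. Among the compounds with values here, no measured step touches this ring position, so none of them bears on the change, and the data give no direction for it. The step from compound 2 to compound 4 in this assay is therefore expected to be small, a 1.0-fold higher number from compound 2 to compound 4 (0.02 log units; within the scatter), with no change beyond the scatter foreseen.

For compound 4 the expected value in this assay is 35 mg/kg, estimated to lie between 14 mg/kg and 90 mg/kg.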

Compound 4, dose for half-maximal effect: 78 mg/kg
Compound 4: the middle estimate sits 2.2-fold (0.35 log units) below what was measured, within the range that was stated.
By their numbers in this assay, from the lowest: compound 3; then compounds 1 and 2 (each within the scatter of the next); then compound 4.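

In this assay, within the data shown here, exchanging bromo for methyl on the aromatic carbon gives a 2.3-fold higher number from compound 2 to compound 4 (0.36 log units; beyond the scatter) and so shows for the first time that this ring position affects the read-out: a modest step, but one that takes compound 4 to a larger dose for the same effect. Among these compounds, until now every measured step concerned the group on the amide-type nitrogen, so this is the first sign that the dose depends on the ring substituent as well. The two groups count alike, each with one heavy atom and neither with a hydrogen-bond donor or acceptor, so these counts do not separate them, and no supporting measurement is available to say what lies behind the step.

From the compounds shown here alone, this single exchange was read with the allyl group on the nitrogen, so it remains open whether methyl in place of bromo would move the number in the same direction with the propargyl or cyclopropyl group there. Also open, going by these compounds, is how other groups at this position, such as chloro, methoxy or a carboxylic acid, would compare with bromo.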